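The source may hold more compounds than are shown below. What is called first, only, known or untested is meant among the compounds shown, and "the series" means these compounds.

Among the measured compounds shown here, in a functional assay on MCF7 cells (Homo sapiens) for antiproliferative activity, read by MTT assay, with a stated time of 72 h (on this read-out higher numbers stand for weaker inhibition and lower numbers for stronger inhibition), compound 3 `CCn1cc(C(CC)(CC)c2ccc(C#CC(O)(CC)CC)c(C)c2)cc1C(=O)NCC(=O)OC` gives 26500 nM, the only true number. Compound 1 `CCn1c(C(=O)On2nnc3ccccc32)ccc1C(CC)(CC)c1ccc(C#CC(O)(CC)CC)c(C)c1` reads > 50000 nM, which is a limit of the assay. Compound 2 `CCCCC(=O)c1ccc(C(CC)(CC)c2ccc(C#CC(O)(CC)CC)c(C)c2)n1CC` reads > 50000 nM, also a limit. Compound 4 `CCN(CC)CCNC(=O)c1cc(C(CC)(CC)c2ccc(C#CC(O)(CC)CC)c(C)c2)cn1CC` differs from compound 3 by (diethylamino)methyl in place of methoxycarbonyl on a saturated chain carbon bound to an amide-type nitrogen: (diethylamino)methyl in place of methoxycarbonyl, on a saturated chain carbon bound to an amide-type nitrogen. For the measured compounds named here, the only measured step, a step that the two limits leave unreadable from compound 1 to compound 2, has no readable size and concerns a change on a carbonyl carbon, so it does not bear on this change. The expectation therefore stays with compound 3 at 26500 nM, and no shift beyond the scatter is expected in this assay. The expected step is a 1.2-fold lower number from compound 3 to compound 4 (0.08 log units; within the scatter). For compound 4 the estimate is 22000 nM, with an expected range of 8000 nM to 50000 nM.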

Compound 4, half-maximal inhibitory concentration: 1800 nM
The estimate for compound 4 lay 12-fold (1.09 log units) above the measured number; measured number outside the range, below it.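

In this assay, the group on the saturated chain carbon bound to an amide-type nitrogen proves able to move the read-out: (diethylamino)methyl in place of methoxycarbonyl gives a 15-fold lower number from compound 3 to compound 4 (1.17 log units; beyond the scatter). Among the compounds shown here, this is the first step of readable size, and it lies beyond the scatter. The earlier step cannot be read, as both of its values are limits: the limit of > 50000 nM in this assay, at which 2 of the 4 values shown sit.

Whether the diethylamino group itself accounts for the step remains open, with a single pair bearing on it. A dimethylamino group, a carboxylic acid or a longer chain carrying the diethylamino group would test this.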